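Working notes: trifluoromethyl series, the step to compound 3

This account rests on a few compounds, and the source may have more. Where it says the series, first, only, none or still open, it means among the compounds named here.

- compound 1 `CN(C)CCCCNc1nc2cc([N+](=O)[O-])ccc2nc1NCc1ccc(C(F)(F)F)cc1`: 9.73 ug/mL
- compound 2 `CN(C)CCCNc1nc2cc([N+](=O)[O-])ccc2nc1NCc1ccccc1C(F)(F)F`: 24.7 ug/mL

Both values come from an ADME assay on HEK293 cells (Homo sapiens) for cytotoxicity, read by MTT assay, with a stated time of 24 h; a higher number here means a weaker inhibitor, a lower number a stronger inhibitor. Compound 2 holds the higher number of the two, and its gap to compound 1 lies beyond the scatter.

Compound 3 `CN(C)CCCNc1nc2cc([N+](=O)[O-])ccc2nc1NCc1ccc(Cl)c(C(F)(F)F)c1` carries 4-chloro-3-(trifluoromethyl)phenyl in place of 2-(trifluoromethyl)phenyl on a saturated chain carbon bound to a nitrogen on an aromatic ring. Within the data shown here, no measured pair isolates this change, so any expectation is weakly grounded. A downward step in this assay is expected, near the edge of the scatter, because compound 1 at 9.73 ug/mL shows that a lower number occurs among these compounds. The estimated move is a 1.9-fold lower number from compound 2 to compound 3 (0.28 log units; within the scatter). For compound 3 the estimate is 13 ug/mL, with an expected range from 5.5 ug/mL to 30 ug/mL.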

Compound 3, half-maximal inhibitory concentration: 3.26 ug/mL
For compound 3 the middle estimate is 4.0-fold (0.60 log units) above the measured one; the measured number lies below the stated range.
By their numbers in this assay, from the lowest: compound 3; then compound 1; then compound 2.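

With the chain held constant, putting 4-chloro-3-(trifluoromethyl)phenyl in place of 2-(trifluoromethyl)phenyl on a saturated chain carbon bound to a nitrogen on an aromatic ring gives a 7.6-fold lower number from compound 2 to compound 3 (0.88 log units; beyond the scatter) in this assay and shows that this position alone can move the number beyond the scatter. The step rests on a single pair, and the entering group differs in both its chlorine and the place of its trifluoromethyl, so neither part can be credited separately. No available evidence bears on the reason for this step.

A 4-chlorophenyl or a 3-(trifluoromethyl)phenyl at this place would separate the two parts. Going by these compounds, it also remains open whether the same change gives a similar step on the longer chain of compound 1 or with a morpholine in place of the dimethylamino group.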